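Chloro Substitution on a Phenyl Ring in Mouse Seizure Protection

This account rests on a few compounds, and the source may have more. Where it says the series, first, only, none or still open, it means among the compounds named here.

Measured compounds:
Compound 1, `OC1CCN(c2ccc(-c3ccccc3)nn2)CC1`, 86 mg/kg
Compound 2, `OC1CCN(c2ccc(-c3cccc(Cl)c3)nn2)CC1`, 45 mg/kg
Compound 3, `O=C1CCN(c2ccc(-c3ccccc3Cl)nn2)CC1`, 40 mg/kg

These three compounds were tested in a functional assay on the whole organism with Mus musculus as the target, in the maximal electroshock model; on this read-out lower numbers stand for an effect already at smaller amounts and higher numbers for an effect only at larger amounts of compound. Compound 1 gives 86 mg/kg, compound 2 gives 45 mg/kg, and compound 3 gives 40 mg/kg.

Compound 2 arises from compound 1 by the change (chloro in place of hydrogen on an aromatic carbon). That change gave a 1.9-fold lower number from compound 1 to compound 2 (0.28 log units; within the scatter), so the two numbers cannot be told apart with confidence. Compound 3 has the lowest of the three numbers; it stands within the scatter of compound 2, but beyond it from compound 1. How the core of compound 3 differs from that of compound 1 is not broken down here.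

The unmeasured compound 4, `O=C1CCN(c2ccc(-c3ccc(Cl)cc3Cl)nn2)CC1`, arises from compound 3 by the change (chloro in place of hydrogen on an aromatic carbon). Within the data shown here, this is the same kind of change as the one from compound 1 to compound 2, but not the same: here the entering group sits meta to a chloro group (1 heavy atom) and para to a large group, whereas in compound 2 it sits meta to a large group.

For compound 4 in this assay a step of about a 1.5-fold lower number from compound 3 to compound 4 (0.17 log units; within the scatter) is expected, resting on the small step of a 1.9-fold lower number from compound 1 to compound 2 (0.28 log units; within the scatter) that the same kind of change produced. Compound 4 is therefore estimated at 27 mg/kg, with a likely range from 14 mg/kg to 55 mg/kg.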

Compound 4, dose for half-maximal effect: 5 mg/kg
Beside the measured number, compound 4's estimate is 5.4-fold (0.73 log units) above it; the whole stated range lies above it.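

Chloro in place of hydrogen on an aromatic carbon gave an 8.0-fold lower number from compound 3 to compound 4 (0.90 log units; beyond the scatter) in this assay and thus a step that stands clear of the usual noise, so on the core of compound 3 this small change counts for a great deal. The change does not carry over at a fixed size from one core to another in this series, since the two cases disagree: the same change on two cores in this assay, a 1.9-fold lower number (0.28 log units; within the scatter) from compound 1 to compound 2 and an 8.0-fold lower number (0.90 log units; beyond the scatter) from compound 3 to compound 4, 4.2-fold (0.62 log units) apart, beyond the scatter of two such steps. What this does not show is the reason for the gap: the two cases differ in the core and also in the place of the new chloro, which in compound 4 sits meta to a chloro group and para to a large group, and two steps alone cannot separate these influences.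

The compounds shown leave open whether the large step belongs to chloro itself or would also appear with another group in that place, such as fluoro, methyl, methoxy or an amine. They also leave open what a second chloro would do on the core of compound 1, which would show whether the large step needs the core of compound 3.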